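The source may report more compounds than this note shows. Statements on the series, on what has been measured and on what is new or still open speak of the compounds shown alone.

Within the data shown here, in a functional assay on A2780 cells (Homo sapiens) for inhibition, read by sulforhodamine B assay, with a stated time of 72 h (on this read-out lower numbers stand for stronger inhibition and higher numbers for weaker inhibition), compound 1 `O=C(NCc1ccc(S(=O)(=O)c2ccccc2)cc1)c1cc2ccncc2s1` gives 14 nM, the lowest number among the compounds measured so far. Compound 3 `O=C(NCc1ccc(S(=O)(=O)N2CCCCC2)cc1)c1cc2ccncc2[nH]1` has the nearest number, at 1700 nM, well beyond the usual scatter of repeats. Compound 2 `O=C(NCc1ccc(S(=O)(=O)c2ccccc2)cc1)c1ccc2cnccc2c1` differs from compound 1 only in the group on the carbonyl carbon. For compound 2, > 10000 nM is a limit of the assay rather than a number.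

Compound 4 `O=C(NCc1ccc(S(=O)(=O)c2ccccc2)cc1)c1cn2ccnc2cn1` has not yet been measured. It also keeps the rest of compound 1 and changes that same group: a group of 9 heavy atoms (6 carbon, 3 nitrogen; one five-membered aromatic ring with 2 hetero atoms, one six-membered aromatic ring with 2 hetero atoms) in place of a group of 9 heavy atoms (7 carbon, 1 nitrogen, 1 sulfur; one five-membered aromatic ring with 1 hetero atom, one six-membered aromatic ring with 1 hetero atom), on a carbonyl carbon. Among the measured compounds shown here, no measured pair covers this exact change, so the expectation is indirect. A large step towards weaker inhibition in this assay, beyond the scatter, is expected, resting on compound 2, whose > 10000 nM is again a limit. The estimated change is a 140-fold higher number from compound 1 to compound 4 (2.15 log units; beyond the scatter). For compound 4 the expected value is 2000 nM, with an estimated range from 200 nM to 10000 nM.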

Compound 4, half-maximal inhibitory concentration: > 10000 nM
Compound 4 gave a limit, no number (the forecaster's own chance of this, stated with the estimate: 35%); middle value at least 5.0-fold (0.69 log units) away from the limit.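

In this assay, a second replacement of the group on the carbonyl carbon gives an at least 710-fold higher number from compound 1 to compound 4 (2.85 log units; beyond the scatter), and this step is open-ended, as compound 4 gave a limit and not a number. Compound 4 now sits with compound 2, so two different groups on this carbonyl carbon, each with the rest of compound 1 unchanged, end at the same limit: the limit of > 10000 nM in this assay, at which 2 of the 4 values shown sit. Among the compounds that keep the rest of compound 1, only compound 1 itself, the one whose group holds sulfur, gives a measurable number.

On these data alone, how much inhibition compounds 2 and 4 retain stays unknown, and so does whether the sulfur atom or the nitrogen atoms of these groups account for the difference. Also open, as far as these compounds go, is whether an amine or a carboxylic acid added to the group of compound 1 would keep its low number.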